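The compounds below may be only part of what the source reports. "The series", "measured", "known", "first", "only" and "open" are said of these compounds alone.

Measured so far:
Compound 1, `CC(C)(C)Cc1c(-c2ccc(Cl)cc2)sc(N)c1C(=O)c1ccc(Cl)cc1`: in an assay on CHO cells for displacement of a labelled ligand from adenosine receptor A3 (Homo sapiens), read by scintillation counting, tested at 10 uM (a higher number here means more inhibition at the concentration tested (going by the name of the read-out), a lower number less inhibition), compound 1 gives 1%.
Compound 2, `CC(C)(C)Cc1c(/C=C/c2ccc(Cl)cc2)sc(N)c1C(=O)c1ccc(Cl)cc1`: in this assay compound 2 gives 11%.

Going by the values given here, of these two numbers compound 2 carries the higher one, but the only measured step, a number 10 percentage points higher from compound 1 to compound 2 (within the scatter), lies within the scatter, so the two compounds cannot be told apart on this evidence. Compound 3, `Cc1ccccc1-c1sc(N)c(C(=O)c2ccc(Cl)cc2)c1CC(C)(C)C`, is the next to be measured. It differs from compound 2 in one place: 2-methylphenyl in place of 2-(4-chlorophenyl)ethenyl on an aromatic carbon. Among the compounds with values here, only one measured step bears on this change; it exchanged 4-chlorophenyl for 2-(4-chlorophenyl)ethenyl on the same aromatic carbon and stayed within the scatter. Compound 1, with 4-chlorophenyl on that aromatic carbon, gave 1%. Compound 3 again carries a six-membered aromatic ring of carbon only on that carbon, so no step beyond the scatter is expected: a number 7 percentage points lower from compound 2 to compound 3 (within the scatter). Compound 3 is estimated at 4%, with a range from -6% to 16%.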

Compound 3, a percentage reported as inhibition, at one concentration (the size of the read-out at that concentration, not a potency): 1%
Estimate against measurement, compound 3: 3 percentage points above; the range from low to high includes it.
By their numbers in this assay, from the lowest: compounds 1, 3 and 2 (each within the scatter of the next).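

At the aromatic carbon next to the ring sulfur, 2-methylphenyl in place of 2-(4-chlorophenyl)ethenyl gives in this assay a number 10 percentage points lower from compound 2 to compound 3 (within the scatter) and 2-methylphenyl in place of 4-chlorophenyl gives no change at the digits printed from compound 1 to compound 3 (within the scatter). Three different groups have now stood on this carbon, one of them with a double bond outside the aromatic rings and one with a methyl group instead of a chlorine, without a single step beyond the scatter. So far, no group at this position sets itself apart from the others.

All three groups carry a six-membered aromatic ring of carbon only, so the compounds shown say nothing about an amine, a carboxylic acid or a longer alkyl chain on this carbon. Nothing at hand bears on why these numbers lie where they do.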